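The source may report more compounds than this note shows. Statements on the series, on what has been measured and on what is new or still open speak of the compounds shown alone.

Measured so far: compound 1 `CN(c1cccc2c1CCCC2c1c[nH]cn1)S(C)(=O)=O` gives 204 nM in an assay on isolated protein for binding affinity to Alpha-1A adrenergic receptor (Rattus norvegicus), read by radioligand binding; on this read-out higher numbers stand for weaker inhibition and lower numbers for stronger inhibition; compound 2 `CCCS(=O)(=O)Nc1cccc2c1CCCC2c1c[nH]cn1` gives 1700 nM.

Compound 2 stands at the higher of the two numbers in this assay; its only neighbour is compound 1, and the single step shown, an 8.3-fold higher number from compound 1 to compound 2 (0.92 log units; beyond the scatter), separates them. Compound 3 `CC(C)S(=O)(=O)Nc1cccc2c1CCCC2c1c[nH]cn1` has not been measured. It differs from compound 2 in one place: isopropyl in place of propyl on a sulfonyl sulfur. For the measured compounds named here, no measured step changes the chain on the sulfonyl sulfur by itself; the step from compound 1 to compound 2 alters both the sulfonyl substituent and the sulfonamide nitrogen at once, so it bears only loosely on the present change. With nothing shown that sets propyl against isopropyl, the step to compound 3 is estimated rather than measured: it is expected to stay within the scatter of this assay, a 1.1-fold lower number from compound 2 to compound 3 (0.05 log units; within the scatter), with no direction favoured. Compound 3 is therefore estimated at 1500 nM, with a range from 600 nM to 4000 nM.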

Compound 3, inhibition constant: 1150 nM
The estimate for compound 3 lay 1.3-fold (0.12 log units) above the measured number; measured number inside the range.
By their numbers in this assay, from the lowest: compound 1; then compounds 3 and 2 (each within the scatter of the next).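

In this assay, for the compounds shown here, the exchange of propyl for isopropyl on a sulfonyl sulfur (a 1.5-fold lower number from compound 2 to compound 3 (0.17 log units; within the scatter)) is the first change confined to this chain, and it does not separate the two groups. The gap to compound 1 persists with the isopropyl group (a 5.6-fold higher number from compound 1 to compound 3 (0.75 log units; beyond the scatter)), so the distance seen earlier is not particular to propyl: methyl(methylsulfonyl)amino stands apart from both (propylsulfonyl)amino and (isopropylsulfonyl)amino. No supporting data bear on why these numbers fall as they do.

On these data alone, compound 1 differs from compound 2 and compound 3 in both the sulfonyl chain and the sulfonamide nitrogen, so the share of each in the gap remains open. Also open, as far as these compounds go, is whether a longer chain such as butyl, or a phenyl ring on the sulfonyl sulfur, would move the number beyond the scatter.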